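Ether variation on the aryloxy side chain of the core

The source may report more compounds than this note shows. Statements on the series, on what has been measured and on what is new or still open speak of the compounds shown alone.

Three compounds share the core of compound 1 `CC(C)Oc1nc(C(C)(C)C)ccc1CNC(=O)C(C)c1ccc(NS(C)(=O)=O)c(F)c1` and differ only in the group on the oxygen on the aromatic ring. In an assay on cells for antagonist activity at transient receptor potential cation channel subfamily V member 1 (Homo sapiens), read by FLIPR and calcium flux, with a stated time of 6 min (on this read-out higher numbers stand for weaker inhibition and lower numbers for stronger inhibition), compound 1 gives 2.3 nM. Compound 2 `CC(C)CCOc1nc(C(C)(C)C)ccc1CNC(=O)C(C)c1ccc(NS(C)(=O)=O)c(F)c1` carries isopentyl and gives 0.8 nM. Compound 3 `CC(C(=O)NCc1ccc(C(C)(C)C)nc1OC1CCCC1)c1ccc(NS(C)(=O)=O)c(F)c1` carries cyclopentyl and gives 1.5 nM. For the measured compounds named here, the move a 2.9-fold lower number from compound 1 to compound 2 (0.46 log units; beyond the scatter) is the only change in this set that clears the scatter; the moves a 1.5-fold lower number from compound 1 to compound 3 (0.19 log units; within the scatter) and a 1.9-fold higher number from compound 2 to compound 3 (0.27 log units; within the scatter) do not. Compound 3 therefore sits with its value inside the scatter of both compound 1 and compound 2, and no ranking among the three can be drawn.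

Compound 4 `CCOCCOc1nc(C(C)(C)C)ccc1CNC(=O)C(C)c1ccc(NS(C)(=O)=O)c(F)c1` is not yet measured. Relative to compound 3 the change is 2-ethoxyethyl in place of cyclopentyl on an oxygen on an aromatic ring. The step that bears most directly on it is a 1.9-fold higher number from compound 2 to compound 3 (0.27 log units; within the scatter), which exchanged two groups of the same heavy-atom count without clearing the scatter; the step of a 1.5-fold lower number from compound 1 to compound 3 (0.19 log units; within the scatter) also stayed within it. Going by the values given here, no measured step introduces an ether oxygen into this chain, so nothing in the set speaks for a shift in either direction. For compound 4 a step of a 1.1-fold higher number from compound 3 to compound 4 (0.05 log units; within the scatter) is expected, within the scatter. Compound 4 is estimated at 1.7 nM, with a range from 0.7 nM to 4 nM.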

Compound 4, inhibition constant: 23.9 nM
For compound 4 the middle estimate is 14-fold (1.15 log units) below the measured one, and the stated range ends below it.
By their numbers in this assay, from the lowest: compounds 2, 3 and 1 (each within the scatter of the next, the first and the last beyond it); then compound 4.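

In this assay the group on an oxygen on an aromatic ring had so far shown only modest differences, but it is not indifferent to what stands there: a 16-fold higher number from compound 3 to compound 4 (1.20 log units; beyond the scatter), although the heavy-atom count is the same and the ring gives way to an open chain carrying one hydrogen-bond acceptor. An open chain alone does not account for the result, as the isopentyl chain of compound 2 is the lowest of the earlier values and a 30-fold higher number from compound 2 to compound 4 (1.48 log units; beyond the scatter), with ethoxy in place of isopropyl on a saturated chain carbon, two bonds along the chain from an oxygen on an aromatic ring. With a 10-fold higher number from compound 1 to compound 4 (1.02 log units; beyond the scatter), compound 4 is the weakest of the four, beyond the scatter of all three others, and no measurement at hand gives a reason for this.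

The compounds shown do not separate the presence of the ether oxygen from its place in the chain, a question that a straight pentyl chain and a 3-methoxypropyl group on the same oxygen could address. From the compounds shown here alone, it also remains open whether a 2-hydroxyethyl or 2-aminoethyl chain would fall with 2-ethoxyethyl or with the carbon-only groups.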